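The source may hold more compounds than are shown below. What is called first, only, known or untested is meant among the compounds shown, and "the series" means these compounds.

Working notes on the nitrofuran carboxamide series.

Three compounds share the same core. Compound 1 `O=C(Nc1nc(-c2cccc(OC3CCCC3)c2)cs1)c1ccc([N+](=O)[O-])o1` carries a cyclopentyloxy group on the pendant aryl ring; in an ADME assay on Vero cells (Chlorocebus sabaeus) for cytotoxicity, read by MTT assay, with a stated time of 72 h (a lower number here means a stronger inhibitor, a higher number a weaker inhibitor), compound 1 gives 81100 nM, so it is only a weak inhibitor of cell viability. Compound 2 `Nc1cccc(-c2csc(NC(=O)c3ccc([N+](=O)[O-])o3)n2)c1` carries a free amino group on that ring, and in this assay compound 2 returns "not determined" (no result reported). Compound 3 `O=C(Nc1nc(-c2cccc(NC(=O)C3CCCC3)c2)cs1)c1ccc([N+](=O)[O-])o1` carries a (cyclopentylcarbonyl)amino group there, and in this assay compound 3 likewise returns "not determined" (no result reported). Among the measured compounds shown here, compound 3 therefore stands without any number, and no step between measured compounds is available anywhere in the set: the only number in this assay belongs to compound 1.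

The next compound, compound 4 `CS(=O)(=O)Nc1cccc(-c2csc(NC(=O)c3ccc([N+](=O)[O-])o3)n2)c1`, differs from compound 3 by methylsulfonyl in place of cyclopentylcarbonyl on a nitrogen on an aromatic ring. Because compound 3 has no value, the size of the step from compound 3 to compound 4 in this assay cannot be placed against anything measured, and no direction is claimed for it beyond the scatter.

What can be said rests on compound 1 alone: its weak effect at 81100 nM is taken as the reference for the series. For compound 4 the expected value in this assay is 80000 nM, estimated to lie between 30000 nM and 200000 nM, with a fair chance that only a limit is reported.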

Compound 4, half-maximal inhibitory concentration: < 2820 nM
Compound 4: only a limit was reported (the forecaster's own chance of this, stated with the estimate: 35%); at least 28-fold (1.45 log units) between middle value and limit.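

In this assay, among the compounds shown here, methanesulfonamido in place of cyclopentyloxy on an aromatic carbon gives an at least 28-fold lower number from compound 1 to compound 4 (1.45 log units; beyond the scatter), so the group at this place can move the read-out by a large step, which the earlier compounds, with one number and no step among them, could not show. The value of compound 4 is a limit and not a number, so the step has a known minimum but no known full size: the limit of < 2820 nM in this assay, at which 1 of the 4 values shown sits. The steps that touch compound 2 or compound 3, including the change from (cyclopentylcarbonyl)amino to methanesulfonamido, cannot be read.

The compounds shown leave open whether the lower number goes with the nitrogen on the aromatic ring, with the methylsulfonyl group, or with the loss of the five-membered ring of carbon, and what number lies behind the limit of compound 4. An acetyl group or a cyclopentylsulfonyl group on that same nitrogen would begin to separate these parts of the change.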